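A few compounds are considered here, and "the series" means these few. Any claim that something is new, unique, unknown or untested is made for them only; others in the source may bear on it.

Compound 1 `Oc1ccccc1-c1cc(-c2ccccc2F)cc(-c2ccccc2O)n1`: > 50000 nM (a limit)
Compound 2 `Oc1cccc(-c2cc(-c3ccccc3F)cc(-c3ccccc3O)n2)c1`: 31100 nM

Both compounds were tested in a functional assay on HeLa cells (Homo sapiens) for inhibition; a lower number here means a stronger inhibitor, a higher number a weaker inhibitor. Compound 1 gives > 50000 nM, which is a limit of the assay and not a number. Its standing on the data is therefore only (the limit of > 50000 nM in this assay, at which 1 of the 2 values shown sits).

The next compound to be tested, compound 3 `Oc1ccccc1-c1cc(-c2ccccc2OC(F)(F)F)cc(-c2ccccc2O)n1`, keeps the core of compound 1 and carries trifluoromethoxy in place of fluoro on an aromatic carbon, ortho to a large group: trifluoromethoxy in place of fluoro on an aromatic carbon.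

Among the measured compounds shown here, only one measured step is available, an at least 1.6-fold lower number from compound 1 to compound 2 (0.20 log units; that floor lies within the scatter). It changes a hydroxyphenyl group and leaves the fluoro untouched, so it bears on the new change only indirectly. For the measured compounds named here, no measured step shows what replacing the fluoro does.

Judging from that single small step, only a modest move towards a lower number, or none beyond the scatter, is expected in this assay. The estimated step is an at least 1.4-fold lower number from compound 1 to compound 3 (0.15 log units; that floor lies within the scatter). The expected value for compound 3 is 35000 nM, within an estimated range of 10000 nM to 70000 nM. A reading at the assay limit would be no surprise.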

Compound 3, half-maximal inhibitory concentration: 9750 nM
Estimate against measurement, compound 3: 3.6-fold (0.56 log units) above; the whole stated range lies above it.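

In this assay, the aromatic carbon holding the fluoro, ortho to a large group, proves sensitive to substitution: trifluoromethoxy in place of fluoro gives an at least 5.1-fold lower number from compound 1 to compound 3 (0.70 log units; beyond the scatter). This is the only step shown that is clearly beyond the scatter, unlike the hydroxyphenyl change, which gives an at least 1.6-fold lower number from compound 1 to compound 2 (0.20 log units; that floor lies within the scatter) and whose floor lies within it. Going by these compounds, the true size of the fluoro change remains unknown, and the printed figure is only a floor, because compound 1 stands at a limit of the assay and not at a number: the limit of > 50000 nM in this assay, at which 1 of the 3 values shown sits.

With only fluoro and trifluoromethoxy shown at this position, it remains open whether the change in the number depends on the oxygen, on the fluorines or on the larger group as a whole, a question that a methoxy or a trifluoromethyl group on the same carbon would help to answer. On these data alone, it is also open whether trifluoromethoxy would lower the number in the same way on the core of compound 2, and how an amine or a carboxylic acid at this position would read in this assay.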